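A Propyl Group on a Compound Known Only by Limit

A few compounds are considered here, and "the series" means these few. Any claim that something is new, unique, unknown or untested is made for them only; others in the source may bear on it.

In a functional assay on the whole organism with Mus musculus as the target (a lower number here means that less compound is needed, a higher number that more compound is needed for the effect), compound 1 `CN1CCN(C(=O)/C=C/c2cccc(C(F)(F)F)c2)CC1` gives > 100 mg/kg as a limit of the assay. Compound 2 `CNC(=O)/C(C)=C/c1cccc(C(F)(F)F)c1` gives > 100 mg/kg as a limit as well. Compound 3 `O=C1CCC(O)(c2cccc(C(F)(F)F)c2)N1` gives > 200 mg/kg as a limit too, so no number places it against the other two. Compound 4 `CCCN1C(=O)CCC1(O)c1cccc(C(F)(F)F)c1` differs from compound 3 by propyl in place of hydrogen on an amide-type nitrogen in a ring and has no measured value yet. Among the measured compounds shown here, no pair of measured compounds shows this change, so the expectation is a loose one. A modest downward step in this assay is expected, estimated as an at least 1.3-fold lower number from compound 3 to compound 4 (0.12 log units; that floor lies within the scatter) in the dose needed. For compound 4 the estimated dose is 150 mg/kg with an expected range from 60 mg/kg to 300 mg/kg and another limit remains quite possible.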

Compound 4, dose for half-maximal effect: 200 mg/kg
The estimate for compound 4 lay 1.3-fold (0.12 log units) below the measured number, and the stated range covers the measured number.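

Among the compounds shown here, with propyl in place of hydrogen on an amide-type nitrogen in a ring, this assay gives compound 4 200 mg/kg as the only actual number among the four compounds. The change gives a number no higher from compound 3 to compound 4 (the limit leaves the size open) and so brings no rise in dose at this nitrogen. Its size cannot be read because compound 3 stands at a limit: the limit of > 200 mg/kg in this assay, at which 1 of the 4 values shown sits.

Going by these compounds, whether a longer chain such as butyl, or a propyl chain ending in an amine, would lower the dose at this nitrogen stays open.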